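The source may report more compounds than this note shows. Statements on the series, on what has been measured and on what is new or still open speak of the compounds shown alone.

- Compound 1 `COC1=C(C)C(=O)/C(=C(O)/C=C/c2ccc(Br)cc2)C(=O)C1(C)C`: 3.6 ug/mL
- Compound 2 `COC1=C(C)C(=O)/C(=C(O)/C=C/c2ccc(O)cc2)C(=O)C1(C)C`: 3.8 ug/mL
- Compound 3 `COC1=C(C)C(=O)/C(=C(O)/C=C/c2cc(C)cc(C)c2)C(=O)C1(C)C`: 2.5 ug/mL

These values come from a functional assay on HUVEC cells (Homo sapiens) for cytotoxicity; on this read-out lower numbers stand for an effect already at smaller amounts and higher numbers for an effect only at larger amounts of compound. The three compounds share one core and differ only in the ring group on the chain. The number for compound 3, 2.5 ug/mL, cannot be told apart from the other two. The steps leading to it are a 1.4-fold lower number from compound 1 to compound 3 (0.16 log units; within the scatter) and a 1.5-fold lower number from compound 2 to compound 3 (0.18 log units; within the scatter).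

Compound 4 `COC1=C(C)C(=O)/C(=C(O)/C=C/c2cccs2)C(=O)C1(C)C` keeps the core but changes that group: thiophen-2-yl in place of 3,5-dimethylphenyl on a double-bonded chain carbon bound to a double-bonded chain carbon. Within the data shown here, no thiophen-2-yl compound has been measured yet, so the closest guides are these two swaps of the ring group. The remaining step, a 1.1-fold higher number from compound 1 to compound 2 (0.02 log units; within the scatter), is equally small. No change beyond the scatter is therefore expected. The estimated step is a 1.3-fold higher number from compound 3 to compound 4 (0.11 log units; within the scatter). Compound 4 is estimated at 3.2 ug/mL, with an expected range from 1.6 ug/mL to 6.5 ug/mL.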

Compound 4, concentration for half-maximal effect: 2.5 ug/mL
The estimate for compound 4 lay 1.3-fold (0.11 log units) above the measured number; measured number inside the range.
By their numbers in this assay, from the lowest: compounds 3, 4, 1 and 2 (each within the scatter of the next).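

In this assay, the ring group on the chain can be a five-membered ring holding a sulfur atom as well as a substituted phenyl ring, with no change at the digits printed from compound 3 to compound 4 (within the scatter) and likewise a 1.5-fold lower number from compound 2 to compound 4 (0.18 log units; within the scatter) and a 1.4-fold lower number from compound 1 to compound 4 (0.16 log units; within the scatter) in this set. Across these four compounds, neither the ring size nor the sulfur atom moves the number beyond the scatter. No measurement here accounts for this flat result.

From the compounds shown here alone, it remains open whether any group at this position can shift the number beyond the scatter. A cyclohexyl ring, a pyridine ring, or a phenyl ring carrying an amine or a carboxylic acid would test this.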